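Selenocyanate and diselenide carbamates on MCF7: a phenyl-for-isobutyl step

The source may hold more compounds than are shown below. What is called first, only, known or untested is meant among the compounds shown, and "the series" means these compounds.

Measured compounds:
compound 1, `CC(C)COC(=O)Nc1ccc([Se]C#N)cc1`, 45500 nM
compound 2, `O=C(Nc1ccc([Se][Se]c2ccc(NC(=O)Oc3ccccc3)cc2)cc1)Oc1ccccc1`, 36700 nM

In a functional assay on MCF7 cells (Homo sapiens) for cytotoxicity, read by MTT assay, with a stated time of 72 h (on this read-out lower numbers stand for stronger inhibition of growth and higher numbers for weaker inhibition of growth), compound 1 gives 45500 nM, and compound 2 gives 36700 nM; the two numbers lie within the scatter of one another, so compound 1 stands level with compound 2 on what is shown. Compound 3, `N#C[Se]c1ccc(NC(=O)Oc2ccccc2)cc1`, differs from compound 1 by phenyl in place of isobutyl on an oxygen next to a carbonyl group. Among the compounds with values here, no measured pair shows this change alone, so the expected step from compound 1 to compound 3 in this assay is taken as small, a 1.3-fold lower number from compound 1 to compound 3 (0.11 log units; within the scatter), if anything towards a lower number, given that compound 2 with the same phenyl carbamate gives 36700 nM. Compound 3 is estimated at 35000 nM, with a range from 15000 nM to 80000 nM.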

Compound 3, concentration for total growth inhibition: 35900 nM
Compound 3: middle estimate off by 1.0-fold (0.01 log units), on the low side; the measured number falls inside the stated range.
By their numbers in this assay, from the lowest: compounds 3, 2 and 1 (each within the scatter of the next).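

In this assay, phenyl in place of isobutyl on an oxygen next to a carbonyl group gives a 1.3-fold lower number from compound 1 to compound 3 (0.10 log units; within the scatter). This pair reads the change alone, which compound 1 and compound 2 could not do, and on this read-out phenyl and isobutyl are not told apart at this position. Nothing on hand offers an explanation for this result.

As far as these compounds go, whether an amine, a carboxylic acid or a longer chain at this position would move the number beyond the scatter remains open. So does whether any group here gives a clear separation from isobutyl.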